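Trifluoromethyl for Ethyl at the Weaker End

The source may hold more compounds than are shown below. What is called first, only, known or untested is meant among the compounds shown, and "the series" means these compounds.

Of the compounds shown here, two have been measured in an assay on CHO cells for activation of soluble guanylate cyclase alpha1/beta1 complex (Homo sapiens), read by cGMP accumulation; on this read-out lower numbers stand for an effect already at smaller amounts and higher numbers for an effect only at larger amounts of compound. Compound 1 `COC(=O)N(C)c1c(N)nc(-n2nc(Cc3ccccc3F)c3cc(F)ccc32)nc1N` gives 960 nM. Compound 2 `CCCCc1nn(-c2nc(N)c3c(n2)NC(=O)C3(C)C)c2ccc(Cl)cc12` gives 47000 nM, the highest of the two numbers, with a gap to compound 1 that lies beyond the scatter. Compound 3 `CC1(C)C(=O)Nc2nc(-n3nc(CCC(F)(F)F)c4cc(Cl)ccc43)nc(N)c21` differs from compound 2 by trifluoromethyl in place of ethyl on a saturated chain carbon, two bonds along the chain from an aromatic carbon. No measured pair shows this change, so its effect is unknown from the data shown. The step of a 1.6-fold lower number from compound 2 to compound 3 (0.19 log units; within the scatter) is expected to be small, possibly staying within the scatter. Compound 3 is therefore expected at about 30000 nM, within a range from 8000 nM to 100000 nM.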

Compound 3, half-maximal effective concentration: 87000 nM
The estimate for compound 3 lay 2.9-fold (0.46 log units) below the measured number; low and high end bracket the measured number.
By their numbers in this assay, from the lowest: compound 1; then compounds 2 and 3 (each within the scatter of the next).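

In this assay, trifluoromethyl in place of ethyl on this saturated chain carbon gives a 1.9-fold higher number from compound 2 to compound 3 (0.27 log units; within the scatter), so butyl and 3,3,3-trifluoropropyl cannot be told apart at this position. For the compounds shown here, this is the first measured step at this place, and it shows that the added fluorine atoms leave the number within the scatter on this core. No evidence bears on this result. Going by these compounds, it remains open whether an amine, a carboxylic acid or a longer chain here would produce a step beyond the scatter. On these data alone, whether the same change reads alike on the core of compound 1 also remains open.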